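The compounds below may be only part of what the source reports. "The series", "measured", "known", "first", "only" and "open" are said of these compounds alone.

Measured compounds in a functional assay on A549 cells (Homo sapiens) for cytotoxicity, read by MTT assay, with a stated time of 72 h; on this read-out lower numbers stand for stronger inhibition and higher numbers for weaker inhibition:

compound 1, `COc1cc2c(Oc3ccc(NC(=O)c4cn(-c5ccccc5C)nn4)cc3F)ccnc2cc1OCCCN1CCCCC1`, 3230 nM
compound 2, `COc1cc2c(Oc3ccc(NC(=O)c4cn(-c5c(C)cccc5C)nn4)cc3F)ccnc2cc1OCCCN1CCCCC1`, "not determined" (no result reported)
compound 3, `COc1cc2c(Oc3ccc(NC(=O)c4cn(-c5ccc(F)c(F)c5)nn4)cc3F)ccnc2cc1OCCCN1CCCCC1`, 220 nM

Compound 1 stands highest of the two numbers in hand; the nearest is compound 3, reached by a 15-fold lower number from compound 1 to compound 3 (1.17 log units; beyond the scatter), a change on the aromatic nitrogen. Compound 4, `COc1cc2c(Oc3ccc(NC(=O)c4cn(-c5ccccc5C)nn4)cc3F)ccnc2cc1OCCCN1CCN(C)CC1`, differs from compound 1 elsewhere: 4-methylpiperazin-1-yl in place of piperidin-1-yl on a saturated chain carbon, three bonds along the chain from an oxygen on an aromatic ring. Going by the values given here, no measured step touches this part of the shared core; the one step in hand, from compound 1 to compound 3, alters the ring on the aromatic nitrogen and says nothing about the chain end. With nothing to point either way, the expected step of a 1.1-fold lower number from compound 1 to compound 4 (0.03 log units; within the scatter) is none beyond the scatter. Compound 4 is therefore estimated at 3000 nM in this assay, within 1200 nM to 8000 nM.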

Compound 4, half-maximal inhibitory concentration: 3100 nM
Compound 4: middle estimate off by 1.0-fold (0.01 log units), on the low side, within the range that was stated.
By their numbers in this assay, from the lowest: compound 3; then compounds 4 and 1 (each within the scatter of the next).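

In this assay, going by these compounds alone, this is the first reading at the chain end: a 1.0-fold lower number from compound 1 to compound 4 (0.02 log units; within the scatter). With the 2-methylphenyl group held constant, 4-methylpiperazin-1-yl and piperidin-1-yl at the end of the propyl chain are not told apart by this read-out. No measurement offered here gives a reason for this result.

As far as these compounds go, it remains open whether the two chain ends also read alike with the 3,4-difluorophenyl group of compound 3. From the compounds shown here alone, a morpholin-4-yl group or a dimethylamino group at the chain end, or a longer chain, also remains open.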